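This account rests on a few compounds, and the source may have more. Where it says the series, first, only, none or still open, it means among the compounds named here.

Measured compounds:
- compound 1, `COc1ccc(C[C@H]2COC(=O)[C@@H]2Cc2ccc(OCC(=O)N3CCCCC3)c(OC)c2)cc1OC`: 293000 nM
- compound 2, `COC(=O)[C@@H](NC(=O)CCC(=O)Oc1ccc(C[C@H]2C(=O)OC[C@@H]2Cc2ccc(OC)c(OC)c2)cc1OC)c1c[nH]c2ccccc12`: >= 600000 nM
- compound 3, `COC(=O)[C@@H](NC(=O)CCC(=O)Oc1ccc(C[C@H]2C(=O)OC[C@@H]2Cc2ccc(OC)c(OC)c2)cc1OC)C(C)C`: 64000 nM

In an ADME assay on HeLa cells (Homo sapiens) for cytotoxicity, read by MTT assay (a higher number here means a weaker inhibitor, a lower number a stronger inhibitor), compound 1 gives 293000 nM, the highest of the two numbers shown; compound 3 sits nearest, with a lower number. For compound 2 the value is a limit of this assay, not a number (the limit of >= 600000 nM in this assay, at which 1 of the 3 values shown sits).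

Going by the values given here, the only measured step is an at least 9.3-fold lower number from compound 2 to compound 3 (0.97 log units; beyond the scatter), which sits on a different part of the shared core from the change now followed.

Compound 4 is `COc1ccc(C[C@H]2COC(=O)[C@@H]2Cc2ccc(OCc3cn(-c4ccc(Br)cc4)nn3)c(OC)c2)cc1OC`. It differs from compound 1 by 1-(4-bromophenyl)-1H-1,2,3-triazol-4-yl in place of (piperidin-1-yl)carbonyl on a saturated chain carbon bound to an oxygen on an aromatic ring. Among the compounds with values here, no measured step touches this place, so the expectation leans on the spread of the series alone. A modest step, a 2.0-fold lower number from compound 1 to compound 4 (0.29 log units; within the scatter), is expected, with compound 4 estimated at 150000 nM (range 40000 nM to 500000 nM).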

Compound 4, half-maximal inhibitory concentration: 128000 nM
Compound 4: the middle estimate sits 1.2-fold (0.07 log units) above what was measured; the measured number falls inside the stated range.
By their numbers in this assay, from the lowest: compounds 3 and 4 (each within the scatter of the next); then compound 1. At a limit, above all of these: compound 2.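

In this assay, the saturated chain carbon bound to an oxygen on an aromatic ring is a place where the number moves: 1-(4-bromophenyl)-1H-1,2,3-triazol-4-yl in place of (piperidin-1-yl)carbonyl gives a 2.3-fold lower number from compound 1 to compound 4 (0.36 log units; beyond the scatter), a modest step. The earlier compounds shown here gave no reading at this place. Nothing measured here bears on what lies behind this step.

Open, on these data alone, is whether the bromine, the phenyl ring or the triazole ring carries the step. As far as these compounds go, how a carboxylic acid or a primary amine in this place would read also remains open.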